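Methoxy to Hydroxy: Expected Shift in Cell Growth Inhibition

The source may report more compounds than this note shows. Statements on the series, on what has been measured and on what is new or still open speak of the compounds shown alone.

compound 1, `Cc1cc(O)cc(-c2nn(CC#N)cc2-c2ccnc(-c3ccc(Oc4ccccc4)cc3)c2)c1`: -72%
compound 2, `COc1cc(C)cc(-c2nn(CC#N)cc2-c2ccnc(-c3ccc(N(C)C)cc3)c2)c1`: 5%

In a functional assay on Malme-3M cells (Homo sapiens) for cytotoxicity, read by sulforhodamine B assay, with a stated time of 48 h, tested at 10 uM (a lower number here means a stronger effect, a higher number a weaker effect of the compound at the concentration tested), compound 1 gives -72% and compound 2 gives 5%. For the measured compounds named here, compound 2 thus stands at the higher, weaker end of the two numbers, and its only neighbour, compound 1, lies beyond the usual scatter below it. These two compounds differ in more than one place, so their gap cannot be assigned to any single change.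

Compound 3 `Cc1cc(O)cc(-c2nn(CC#N)cc2-c2ccnc(-c3ccc(N(C)C)cc3)c2)c1` has not yet been measured in this assay. It differs from compound 2 in one place: hydrogen in place of methyl on an oxygen on an aromatic ring. Going by the values given here, no measured pair shows this change on its own. A downward step beyond the scatter is nevertheless expected, because compound 1 gives -72% and carries the same 3-hydroxy-5-methylphenyl group. The expected step is a number 30 percentage points lower from compound 2 to compound 3 (beyond the scatter). For compound 3 the estimate is -25%, within a range from -75% to 10%.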

Compound 3, a percentage reported as activity, at one concentration (the size of the read-out at that concentration, not a potency): -19%
Beside the measured number, compound 3's estimate is 6 percentage points below it; the range from low to high includes it.
By their numbers in this assay, from the lowest: compound 1; then compound 3; then compound 2.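

In this assay the change from methoxy to hydroxy can now be read on its own, with the dimethylamino group held fixed: the read-out moves a number 24 percentage points lower from compound 2 to compound 3 (beyond the scatter) and so crosses from a positive to a negative number. With the 3-hydroxy-5-methylphenyl group held fixed, dimethylamino in place of phenoxy on an aromatic carbon gives the larger move, a number 53 percentage points higher from compound 1 to compound 3 (beyond the scatter), so both places contribute to the gap between the first two compounds, and the phenoxy exchange contributes more. Nothing at hand bears on the cause of either step.

From the compounds shown here alone, whether methoxy to hydroxy gives a step of the same size when phenoxy stands in place of dimethylamino remains open. Also open, going by these compounds, is what an ethoxy group, an amine or a carboxylic acid would give in place of the hydroxy group.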